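Positional Fluorine Shift on the Shared Core

The source may report more compounds than this note shows. Statements on the series, on what has been measured and on what is new or still open speak of the compounds shown alone.

Compound 1, `COc1ccc(/C=N/NC(=O)CSc2nnc(-c3ccncc3)n2-c2ccccc2)cc1`, in a functional assay on HCT-116 cells (Homo sapiens) for inhibition, read by MTT assay, with a stated time of 48 h (on this read-out higher numbers stand for weaker inhibition and lower numbers for stronger inhibition), gives 19200 nM.
Compound 2, `O=C(CSc1nnc(-c2ccncc2)n1-c1ccccc1)N/N=C/c1ccc([N+](=O)[O-])cc1`, in this assay gives 10200 nM.
Compound 3, `O=C(CSc1nnc(-c2ccncc2)n1-c1ccccc1)N/N=C/c1ccc(F)cc1`, in this assay gives 7040 nM.

Among these three, compound 3 sits apart from compound 1 (a 2.7-fold lower number from compound 1 to compound 3 (0.44 log units; beyond the scatter)), while against compound 2 the gap is a 1.4-fold lower number from compound 2 to compound 3 (0.16 log units; within the scatter), so no order between compound 2 and compound 3 can be read. The nitro-for-methoxy exchange gave a 1.9-fold lower number from compound 1 to compound 2 (0.27 log units; within the scatter).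

Compound 4, `O=C(CSc1nnc(-c2ccncc2)n1-c1ccccc1)N/N=C/c1cccc(F)c1`, differs from compound 3 by 3-fluorophenyl in place of 4-fluorophenyl on a carbon with a double bond to nitrogen. Among the measured compounds shown here, all three measured steps swap one substituent for another at a single carbon; none moves a substituent from one carbon of that ring to another, so no measured step bears directly on this change. The closest analogy, that fluoro, nitro and methoxy at the same carbon span a narrow range, suggests this shift is modest as well. For compound 4 in this assay a step of a 1.1-fold higher number from compound 3 to compound 4 (0.03 log units; within the scatter) is expected, that is, nothing beyond the scatter. The estimate for compound 4 is 7500 nM, with a range from 3000 nM to 19000 nM.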

Compound 4, half-maximal inhibitory concentration: > 50000 nM
Compound 4: a limit, no number; the forecaster's own chance of this, stated with the estimate: 3%; middle value at least 6.6-fold (0.82 log units) from the limit.
By their numbers in this assay, from the lowest: compounds 3, 2 and 1 (each within the scatter of the next, the first and the last beyond it). At a limit, above all of these: compound 4.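

In this assay, the value of compound 4 is a limit of the assay and not a number: the limit of > 50000 nM in this assay, at which 1 of the 4 values shown sits.

Exchanging 4-fluorophenyl for 3-fluorophenyl, with the same atoms joined differently, gave an at least 7.1-fold higher number from compound 3 to compound 4 (0.85 log units; beyond the scatter), which shows that where the fluorine sits on this ring matters in this assay, something the earlier exchanges of one substituent for another at a single carbon could not show. The 3-fluorophenyl compound also stands apart from the other two, with an at least 4.9-fold higher number from compound 2 to compound 4 (0.69 log units; beyond the scatter) and an at least 2.6-fold higher number from compound 1 to compound 4 (0.41 log units; beyond the scatter), both beyond the scatter.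

The compounds shown leave open whether a chlorine or an amine in place of the fluorine of compound 4 would give a similar result. They also do not tell how far beyond its limit compound 4 lies, or what underlies the step.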